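Tolerance of benzoxazole sulfonamides in a cell-based cytotoxicity assay

The compounds below may be only part of what the source reports. "The series", "measured", "known", "first", "only" and "open" are said of these compounds alone.

Measured so far:
compound 1 `Cc1ccc(S(=O)(=O)Nc2ccc(-c3nc4ccccc4o3)cc2)cc1`: 88000 nM
compound 2 `Cc1ccc(S(=O)(=O)Nc2ccc3oc(-c4ccccc4)nc3c2)cc1`: 75000 nM
compound 3 `O=S(=O)(Nc1ccc2oc(-c3ccccc3)nc2c1)c1ccc(F)c(C(F)(F)F)c1`: > 100000 nM

The read-out throughout is an ADME assay on HEK293 cells (Homo sapiens) for cytotoxicity, read by resazurin assay, with a stated time of 48 h; a lower number here means that less compound is tolerated, a higher number that more compound is tolerated. Compound 1 gives 88000 nM, the higher of the two numbers in hand, and compound 2 gives 75000 nM, the gap between them lying within the scatter, so no order between the two can be read from these values. Compound 3 returns only a limit in this assay, > 100000 nM, and the shared limit is the limit of > 100000 nM in this assay, at which 1 of the 3 values shown sits.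

Compound 4 `Cc1cccc(S(=O)(=O)Nc2ccc(-c3nc4ccccc4o3)cc2)c1` has not yet been measured in this assay. It differs from compound 1 by 3-methylphenyl in place of 4-methylphenyl on a sulfonyl sulfur; the two have the same atoms joined differently. Within the data shown here, no measured pair in the set isolates such a change, so the expectation for compound 4 rests on the values of compound 1 and compound 2 alone, which are both large and close to each other. The step from compound 1 to compound 4 is expected to be a 1.0-fold higher number from compound 1 to compound 4 (0.01 log units; within the scatter), that is, none beyond the scatter in either direction. Compound 4 is therefore expected to give about 90000 nM in this assay, within a range of 45000 nM to 180000 nM, with a real chance that only a limit is reported.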

Compound 4, half-maximal cytotoxic concentration: > 100000 nM
Compound 4 gave a limit, no number (the forecaster's own chance of this, stated with the estimate: 35%); middle value at least 1.1-fold (0.04 log units) away from the limit.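

Notes on the sulfonyl position: the move of the methyl gives the first pair in the series that differs in one place, 3-methylphenyl in place of 4-methylphenyl on a sulfonyl sulfur, and in this assay the step reads an at least 1.1-fold higher number from compound 1 to compound 4 (0.05 log units; that floor lies within the scatter). Compound 4 gives > 100000 nM, which is a limit of the assay and not a number. The pair therefore sets only a floor, one that does not separate the two isomers, and it adds a second compound to those that return no number, so the top of the assay now constrains readings in this series: the limit of > 100000 nM in this assay, at which 2 of the 4 values shown sit.

On these data alone, how far compound 4 actually lies from compound 1 stays unknown, so neither an order nor a size can be given for this change, and the values shown cannot say whether the placing of the methyl matters at all in this assay. Also open, as far as these compounds go, is whether an amine or a carboxylic acid on the phenyl group, or a longer chain in place of the methyl, would bring the reading down to a number clearly below the limit.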